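A few compounds are considered here, and "the series" means these few. Any claim that something is new, unique, unknown or untested is made for them only; others in the source may bear on it.

Working notes on the series.

Compound 1 `O=C(Nc1cccc(-n2cc(-c3ccncc3)c(-c3cc(O)cc(Cl)c3)n2)c1)Nc1ccc(Cl)c(C(F)(F)F)c1` carries a urea link and a hydroxy group on the pendant ring; in a functional assay on NCI-H322M cells (Homo sapiens) for inhibition, read by sulforhodamine B assay, with a stated time of 48 h, tested at 10 uM (on this read-out higher numbers stand for a weaker effect at the one concentration tested and lower numbers for a stronger effect), compound 1 gives 45%. Compound 2 `COc1cc(Cl)cc(-c2nn(-c3cccc(NC(=O)Nc4ccc(Cl)c(C(F)(F)F)c4)c3)cc2-c2ccncc2)c1` differs from it only by methyl in place of hydrogen on an oxygen on an aromatic ring, and in this assay compound 2 gives 18.7%. Among the compounds with values here, the step of a number 26.3 percentage points lower from compound 1 to compound 2 (beyond the scatter) is the only measured pair in which this change occurs.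

Compound 3 `O=C(Nc1cccc(-n2cc(-c3ccncc3)c(-c3cc(O)cc(Cl)c3)n2)c1)c1cc(C(F)(F)F)cc(C(F)(F)F)c1` replaces the urea with an amide bearing two trifluoromethyl groups; the difference between the core of compound 3 and the core of compound 1 is not broken down here. In this assay compound 3 gives 74.1%, the highest of the three numbers, with the gaps to compound 1 and compound 2 both beyond the scatter.

Compound 4 `COc1cc(Cl)cc(-c2nn(-c3cccc(NC(=O)c4cc(C(F)(F)F)cc(C(F)(F)F)c4)c3)cc2-c2ccncc2)c1` is not yet measured. It differs from compound 3 by methyl in place of hydrogen on an oxygen on an aromatic ring, the same change as that from compound 1 to compound 2, made at the same place on the same pendant ring. The step of a number 26.1 percentage points lower from compound 3 to compound 4 (beyond the scatter) is expected to resemble the earlier one because compound 1 to compound 2 showed a number 26.3 percentage points lower from compound 1 to compound 2 (beyond the scatter) on a different core, and a single pair is thin evidence, so the range is kept wide. Compound 4 is therefore estimated at 48% in this assay. For compound 4 the lower end of the expectation is 30%. For compound 4 the upper end of the expectation is estimated at 68%.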

Compound 4, a percentage reported as activity, at one concentration (the size of the read-out at that concentration, not a potency): 80.3%
For compound 4 the middle estimate is 32.3 percentage points below the measured one; the whole stated range lies below it.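

In this assay, hydroxy to methoxy on the pendant ring gives a number 6.2 percentage points higher from compound 3 to compound 4 (within the scatter), so on this core the change leaves no difference that can be told from the scatter. Within the data shown here, the lower number seen on the urea core therefore does not carry over to the amide core bearing two trifluoromethyl groups, and the size of this step has to be judged separately on each core: the same change on two cores in this assay, a number 26.3 percentage points lower (beyond the scatter) from compound 1 to compound 2 and a number 6.2 percentage points higher (within the scatter) from compound 3 to compound 4, 32.5 percentage points apart, beyond the scatter of two such steps This does not show which feature of the cores separates the two results, as they differ both in the link and in the ring it carries; with only two pairs, each read at a single concentration, it also gives no general rule for this change and no measure of potency.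

The compounds shown leave open whether a urea link carrying the ring of compound 3, or an amide link carrying the ring of compound 1, would follow the urea or the amide result, which would separate the link from the ring. They also leave open how an ethoxy group or a longer alkoxy chain on the same oxygen, or an amine in place of the hydroxy group, would read on each core.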